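This account rests on a few compounds, and the source may have more. Where it says the series, first, only, none or still open, it means among the compounds named here.

Working notes on the series built on the shared core of compound 1 `C=CC(=O)Nc1cccc(-c2nc3ccccc3s2)c1`. In an ADME assay on Raji cells (Homo sapiens) for inhibition, with a stated time of 72 h (a lower number here means that less compound is needed, a higher number that more compound is needed for the effect), compound 1 gives only the assay limit > 25000 nM. Compound 2 `O=C(O)/C=C/C(=O)Nc1cccc(-c2nc3ccccc3s2)c1` likewise reaches only a limit in this assay, > 25000 nM. Compound 3 `O=C(Nc1cccc(-c2nc3ccccc3s2)c1)c1cccnc1Cl` also stops at a limit, > 25000 nM. All three values sit on the same limit (the limit of > 25000 nM in this assay, at which 3 of the 3 values shown sit), so compound 2 stands nowhere readable against its neighbours: the steps a step that the two limits leave unreadable from compound 1 to compound 2, a step that the two limits leave unreadable from compound 1 to compound 3 and a step that the two limits leave unreadable from compound 2 to compound 3 are all unreadable. Compound 4 `O=C(Nc1cccc(-c2nc3ccccc3s2)c1)c1ccncc1Cl` is the next member. Change from compound 2: 3-chloropyridin-4-yl in place of 2-carboxyethenyl on a carbonyl carbon. Going by the values given here, the one measured step that resembles it, a step that the two limits leave unreadable from compound 2 to compound 3, is unreadable, so no step in this assay beyond the scatter can be expected in either direction. For compound 4 the estimate is 30000 nM with a range of 10000 nM to 100000 nM. The implied step is expected to be a step that the limit leaves unreadable from compound 2 to compound 4, most likely again reported only as a limit.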

Compound 4, half-maximal effective concentration: > 25000 nM
Compound 4: no number, only a limit (the forecaster's own chance of this, stated with the estimate: 75%); the middle value lies beyond the limit too.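

In this assay compound 4 gives only a limit, > 25000 nM, and its steps from compound 1, compound 2 and compound 3 cannot be read: the limit of > 25000 nM in this assay, at which 4 of the 4 values shown sit.

Going by these compounds, whether any of these groups on the carbonyl carbon alters the half-maximal effective concentration in this assay stays open.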